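A Fluoro Added to the Benzylsulfanyl Arm

A few compounds are considered here, and "the series" means these few. Any claim that something is new, unique, unknown or untested is made for them only; others in the source may bear on it.

Of the compounds shown here, three sharing one core have been measured in a functional assay on the whole organism (artery, strain albino) with Rattus norvegicus as the target, with a stated time of 120 min, at a dose of 10 mg/kg by the oral route; on this read-out higher numbers stand for more inhibition at the one dose given (going by the name of the read-out) and lower numbers for less inhibition. Compound 1 `COc1ccc(C2N=C(SCc3ccccc3)NC(C)=C2C(=O)Nc2ccc(F)cc2)cc1OC` gives 8.8% in this assay. Compound 2 `CC1=C(C(=O)Nc2ccc(Br)cc2)C(c2ccc(Cl)cc2Cl)N=C(SCc2ccccc2)N1` gives 10.3%, and compound 3 `COc1ccc(C2N=C(SCc3ccccc3)NC(C)=C2C(=O)Nc2ccc(Br)cc2)cc1` gives 8.2%. Compound 3 sits at the lower edge of the three numbers, yet both compound 1 and compound 2 lie within the usual scatter of it, so no order among the three can be read. The only single-point step shown, a number 2.1 percentage points lower from compound 2 to compound 3 (within the scatter), concerns a change of the aryl group on the saturated ring carbon and stays within the scatter.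

Compound 4 `COc1ccc(C2N=C(SCc3ccc(F)cc3)NC(C)=C2C(=O)Nc2ccc(Br)cc2)cc1` differs from compound 3 by fluoro in place of hydrogen on an aromatic carbon. Read one bond further out, the change is benzylsulfanyl to (4-fluorobenzyl)sulfanyl, a place that no measured step touches. For the measured compounds named here, with nothing bearing directly on this change and the one known step being flat, for compound 4 the expected step of a number 0.8 percentage points higher from compound 3 to compound 4 (within the scatter) is none beyond the scatter. Compound 4 is therefore estimated at 9%, within 2% to 18%.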

Compound 4, a percentage reported as inhibition, in the whole organism at one dose (the size of the read-out at that dose, not a potency): 12.9%
Estimate against measurement, compound 4: 3.9 percentage points below; the range from low to high includes it.
By their numbers in this assay, from the lowest: compounds 3, 1, 2 and 4 (each within the scatter of the next).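

For the compounds shown here, this is the first reading on the benzylsulfanyl arm, a place the earlier compounds left untouched: fluoro in place of hydrogen gives a number 4.7 percentage points higher from compound 3 to compound 4 (within the scatter) and so stays inside the scatter. At this one oral dose, the change from benzylsulfanyl to (4-fluorobenzyl)sulfanyl therefore shows no readable effect in either direction, and this single pair cannot separate a small real step from repeat-to-repeat variation. No measurement offered here explains the result.

The compounds shown leave open whether a chloro or a methoxy group on that aromatic carbon, or a phenethyl chain in place of benzyl, would give a step beyond the scatter in this assay. They also leave open whether the same fluoro would read alike with the 2,4-dichlorophenyl group of compound 2.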